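Swapping the sulfur-linked heterocycle: from thiadiazole to thiazoline

A few compounds are considered here, and "the series" means these few. Any claim that something is new, unique, unknown or untested is made for them only; others in the source may bear on it.

The three measured compounds, each read in a functional assay on MCF7 cells (Homo sapiens) for cytotoxicity, read by MTT assay, with a stated time of 24 h, tested at 6.4 ug/mL; a higher number here means a stronger effect of the compound at the concentration tested, a lower number a weaker effect:
compound 1, `Cn1c(-c2ccc(NC(=O)CSc3nc4ccccc4o3)cc2)nc(-c2ccccc2)c1-c1ccccc1`, gives 42.3%;
compound 2, `Cn1cnnc1SCC(=O)Nc1ccc(-c2nc(-c3ccccc3)c(-c3ccccc3)n2C)cc1`, gives 59.2%;
compound 3, `Cc1nnc(SCC(=O)Nc2ccc(-c3nc(-c4ccccc4)c(-c4ccccc4)n3C)cc2)s1`, gives 67.8%.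

Compound 3 holds the highest number of the three in this assay. Its gap to compound 1 is beyond the scatter, a number 25.5 percentage points higher from compound 1 to compound 3 (beyond the scatter), whereas the step of a number 8.6 percentage points higher from compound 2 to compound 3 (within the scatter) lies within the scatter, so compounds 2 and 3 cannot be ordered against each other. The third step, a number 16.9 percentage points higher from compound 1 to compound 2 (beyond the scatter), runs in the same direction as the first.

Compound 4, `Cn1c(-c2ccc(NC(=O)CSC3=NCCS3)cc2)nc(-c2ccccc2)c1-c1ccccc1`, has not yet been measured in this assay. It differs from compound 3 in one place: a group of 5 heavy atoms (3 carbon, 1 nitrogen, 1 sulfur; one five-membered non-aromatic ring with 2 hetero atoms) in place of a group of 6 heavy atoms (3 carbon, 2 nitrogen, 1 sulfur; one five-membered aromatic ring with 3 hetero atoms), on a sulfur. The measured steps all exchange one aromatic group on that sulfur for another aromatic group, and both smaller aromatic rings gave higher numbers than the 1,3-benzoxazol-2-yl ring of compound 1. For the measured compounds named here, no measured step introduces a non-aromatic ring, so those steps bear on this change only loosely. Compound 4 is therefore expected to land somewhat below compound 3, with a step of a number 12.8 percentage points lower from compound 3 to compound 4 (beyond the scatter) that may well stay within the scatter. The estimate for compound 4 in this assay is 55%, with a range from 38% to 72%.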

Compound 4, a percentage reported as activity, at one concentration (the size of the read-out at that concentration, not a potency): 18.6%
Compound 4: middle estimate off by 36.4 percentage points, on the high side; measured number outside the range, below it.
By their numbers in this assay, from the lowest: compound 4; then compound 1; then compounds 2 and 3 (each within the scatter of the next).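

In this assay, the place on the sulfur proved far more sensitive to the kind of ring than the exchanges among aromatic groups had shown: the five-membered non-aromatic ring of compound 4 brings a fall (a number 49.2 percentage points lower from compound 3 to compound 4 (beyond the scatter); a number 40.6 percentage points lower from compound 2 to compound 4 (beyond the scatter)), and both steps are larger than any seen among compounds 1, 2 and 3. The 1,3-benzoxazol-2-yl group, which had given the lowest number, now stands above the new ring (a number 23.7 percentage points lower from compound 1 to compound 4 (beyond the scatter)), so the earlier pairing of smaller aromatic rings with higher numbers does not extend to compound 4, the group with the fewest heavy atoms. No measurement at hand offers an explanation for this fall.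

On these data alone, whether an aromatic 1,3-thiazol-2-yl ring on the same sulfur would stay with compounds 2 and 3 or fall towards compound 4 remains open, and with it whether the loss follows the non-aromatic ring or the particular ring atoms. As far as these compounds go, how an open chain on that sulfur, such as a 2-aminoethyl group, would read is also open, as is whether this order holds at other concentrations.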